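The source may hold more compounds than are shown below. What is called first, only, known or untested is meant among the compounds shown, and "the series" means these compounds.

In an ADME assay on the whole organism (Mus musculus, strain CD-1) for pharmacokinetics, at a dose of 10 mg/kg by the oral route (a lower number here means less compound in the circulation, a higher number more compound in the circulation at the dose given), two compounds have been measured:

Compound 1 `CCOc1cc([C@](O)(CCN(C)C)[C@@H](c2cc3cc(Br)ccc3nc2OC)c2ccnc(OC)c2OC)cc(OC)n1`: 12700 ng.h/mL
Compound 2 `COc1cc([C@](O)(CCN(C)C)[C@@H](c2cc3cc(Br)ccc3nc2OC)c2ccnc(OC)c2OC)cc(OC(C)C)n1`: 5600 ng.h/mL

Compound 2 holds the lower of the two numbers. Within the data shown here, the gap between them is the only measured step, a 2.3-fold lower number from compound 1 to compound 2 (0.36 log units; beyond the scatter), which is modest but beyond the scatter. Compound 3 `CCOc1cc([C@](O)(CCN(C)C)[C@@H](c2cc3cc(Br)ccc3nc2OC)c2ccnc(OC)c2OC)cc(OC(C)C)n1` has not yet been measured. It differs from compound 2 by methyl in place of hydrogen on a saturated chain carbon bound to an oxygen on an aromatic ring, which is methyl in place of hydrogen on a saturated chain carbon bound to an oxygen on an aromatic ring, or methoxy to ethoxy. The measured step is also methyl in place of hydrogen, but it falls on a different group, so this single precedent is only a rough guide. Going by a 2.3-fold lower number from compound 1 to compound 2 (0.36 log units; beyond the scatter), a further modest fall in this assay is expected, and the expected step is a 1.6-fold lower number from compound 2 to compound 3 (0.20 log units; within the scatter). For compound 3 the estimated value is 3500 ng.h/mL, with an expected range of 1500 ng.h/mL to 8000 ng.h/mL.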

Compound 3, area under the concentration-time curve: 32000 ng.h/mL
For compound 3 the middle estimate is 9.1-fold (0.96 log units) below the measured one, and the stated range ends below it.
By their numbers in this assay, from the lowest: compound 2; then compound 1; then compound 3.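

In this assay, methyl in place of hydrogen on a saturated chain carbon bound to an oxygen on an aromatic ring gives a 5.7-fold higher number from compound 2 to compound 3 (0.76 log units; beyond the scatter), so this kind of change does not carry a fixed direction from the earlier step, a 2.3-fold lower number from compound 1 to compound 2 (0.36 log units; beyond the scatter). With the ethoxy group in place, isopropyl in place of methyl on an oxygen on an aromatic ring gives a 2.5-fold higher number from compound 1 to compound 3 (0.40 log units; beyond the scatter). Compound 3, which carries both the ethoxy and the isopropyl ether, thus stands above compound 1 and compound 2, with both of its steps beyond the scatter.

Nothing given here explains why the number rises. As far as these compounds go, whether a longer chain, such as propyl, or an amine on the same oxygen would hold this higher number remains open.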